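A few compounds are considered here, and "the series" means these few. Any claim that something is new, unique, unknown or untested is made for them only; others in the source may bear on it.

The measured compounds:
- compound 1 `COC(=O)c1ccc(-c2cnc(C(=O)CCc3ccc(-c4ccccc4)cc3)o2)nc1`, which in an assay for inhibition of Fatty-acid amide hydrolase 1 (Rattus norvegicus) (on this read-out higher numbers stand for weaker inhibition and lower numbers for stronger inhibition), gives 2.2 nM
- compound 2 `N#Cc1cccc(-c2cnc(C(=O)CCc3ccc(-c4ccccc4)cc3)o2)n1`, which in this assay gives 2.9 nM

Compound 2 stands with the higher of the two numbers, but the step between them is only a 1.3-fold higher number from compound 1 to compound 2 (0.12 log units; within the scatter), so the two cannot be told apart. Compound 3 `O=C(CCc1ccc(-c2ccccc2)cc1)c1ncc(-c2cccc(-c3nnn[nH]3)n2)o1` has not yet been measured. It differs from compound 2 in one place: 1H-tetrazol-5-yl in place of cyano on an aromatic carbon. Going by the values given here, no measured step involves a tetrazole. Among the compounds with values here, the only step seen, a 1.3-fold higher number from compound 1 to compound 2 (0.12 log units; within the scatter), exchanges one substituted pyridyl group for another and leaves the number where it was; it shows that one exchange of this kind passed without a shift, but a tetrazole is not among the groups tried, so it gives no direct guide. With that little to go on, compound 3 is expected to land not far from compound 2, with a step of a 2.1-fold higher number from compound 2 to compound 3 (0.32 log units; beyond the scatter) as the most likely outcome and a wide band around it. The estimate for compound 3 in this assay is 6 nM, within a range from 1.5 nM to 30 nM.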

Compound 3, inhibition constant: 25 nM
The estimate for compound 3 lay 4.2-fold (0.62 log units) below the measured number; the measured number falls inside the stated range.
By their numbers in this assay, from the lowest: compounds 1 and 2 (each within the scatter of the next); then compound 3.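

In this assay, replacing the nitrile with 1H-tetrazol-5-yl, on an aromatic carbon next to the ring nitrogen and meta to a large group, gives an 8.6-fold higher number from compound 2 to compound 3 (0.94 log units; beyond the scatter) and so provides the first shift in this set that clearly exceeds the scatter. The earlier exchange gave only a 1.3-fold higher number from compound 1 to compound 2 (0.12 log units; within the scatter) and could have suggested that substituents on this six-membered ring hardly affect the number, but compound 3 shows that the choice of group can matter, even though compound 3 at 25 nM remains a nanomolar inhibitor. The change adds heavy atoms, a five-membered aromatic ring and a hydrogen-bond donor all at once, and nothing available here separates their contributions or explains the higher number.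

A carboxylic acid or a primary amide at this same place would help show whether the higher number goes with the tetrazole ring specifically or extends to other groups carrying a hydrogen-bond donor. As far as these compounds go, it also remains open whether a 1H-tetrazol-5-yl group would give a similar step at the ring position that carries the methoxycarbonyl group in compound 1.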